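The compounds below may be only part of what the source reports. "The series", "measured", "known", "first", "only" and "open" are said of these compounds alone.

Of the compounds shown here, three of this small series have been tested in a functional assay on B16 cells (Mus musculus) for cytotoxicity, read by MTT assay, with a stated time of 48 h (on this read-out higher numbers stand for weaker inhibition and lower numbers for stronger inhibition), and a fourth awaits its reading. Compound 1, `C#Cc1ccc(NC(=O)c2cn(CC(=O)OCC)nn2)cc1`, gives > 100000 nM, which is a limit of the assay rather than a number, namely (the limit of > 100000 nM in this assay, at which 1 of the 3 values shown sits). Compound 2, `C#Cc1ccc(NC(=O)c2cn(CCOC(C)=O)nn2)cc1`, gives 79000 nM. The two share their atoms, joined differently: the change is acetoxymethyl in place of ethoxycarbonyl on a saturated chain carbon bound to an aromatic nitrogen, and it produced an at least 1.2-fold lower number from compound 1 to compound 2 (0.10 log units; that floor lies within the scatter), a step whose floor lies within the usual scatter.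

Compound 3, `CCOC(=O)Cn1cc(CNC(=O)c2cn(Cc3ccccc3)nn2)nn1`, carries a different core; how its core differs from that of compound 1 is not broken down here. In this assay compound 3 gives 35000 nM, the lowest of the two numbers, standing beyond the scatter from compound 2.

Compound 4, `CC(=O)OCCn1cc(CNC(=O)c2cn(Cc3ccccc3)nn2)nn1`, is not yet measured. It differs from compound 3 by acetoxymethyl in place of ethoxycarbonyl on a saturated chain carbon bound to an aromatic nitrogen, the same change, at the same kind of place, that led from compound 1 to compound 2. Since that earlier step gave only a floor within the scatter, the step from compound 3 to compound 4 is expected to be small as well, estimated as a 1.2-fold lower number from compound 3 to compound 4 (0.07 log units; within the scatter). Compound 4 is therefore expected to give about 30000 nM in this assay, most likely between 12000 nM and 80000 nM.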

Compound 4, half-maximal inhibitory concentration: 28000 nM
Compound 4: middle estimate off by 1.1-fold (0.03 log units), on the high side; the range from low to high includes it.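

In this assay, acetoxymethyl in place of ethoxycarbonyl on a saturated chain carbon bound to an aromatic nitrogen gave a 1.3-fold lower number from compound 3 to compound 4 (0.10 log units; within the scatter), and set beside the earlier step the result reads: the same change on two cores in this assay, an at least 1.2-fold lower number (0.10 log units; that floor lies within the scatter) from compound 1 to compound 2 and a 1.3-fold lower number (0.10 log units; within the scatter) from compound 3 to compound 4; the limit leaves it open whether they differ. On neither core, then, does this change give a step that can be told from the scatter, and the second core shows this with a measured number at both ends, although two cores are too few to make a rule for the whole series. What this does not show is that the two steps are equal in size, and compound 1 gives a limit of the assay, not a number: the limit of > 100000 nM in this assay, at which 1 of the 4 values shown sits.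

The compounds shown leave open whether any group at this place would move the number beyond the scatter, such as a carboxylic acid, an amine or a longer chain in place of (ethoxycarbonyl)methyl and 2-acetoxyethyl. Also open, as far as these compounds go, is whether 2-hydroxyethyl, the free alcohol, would read like 2-acetoxyethyl on either core.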